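The compounds below may be only part of what the source reports. "The series", "measured", "known", "first", "only" and "open" are said of these compounds alone.

Measured compounds:
Compound 1 `CC(=O)N1c2ccccc2CCC1C(=O)Nc1ccccc1O` — in a functional assay on NUGC-3 cells (Homo sapiens) for cytotoxicity, read by sulforhodamine B assay, with a stated time of 72 h (a higher number here means a weaker inhibitor of growth, a lower number a stronger inhibitor of growth), compound 1 gives 49700 nM.
Compound 2 `CCCC(=O)N1c2ccccc2CCC1C(=O)Nc1cc(C(F)(F)F)cc(C(F)(F)F)c1` — in this assay compound 2 gives 14400 nM.
Compound 3 `COc1ccc(NC(=O)C2CCc3ccccc3N2)cc1` — in this assay compound 3 gives 51900 nM.

Among these three, compound 2 stands at the lowest number, which in this assay means the strongest inhibition of growth; its gap to compound 1 and to compound 3 is beyond the usual scatter in both cases. Compound 4 `O=C(Nc1cc(C(F)(F)F)cc(C(F)(F)F)c1)C1CCc2ccccc2N1` has not yet been measured. It keeps the shared core and the bis(trifluoromethyl)phenyl amide of compound 2 and differs only in one spot: hydrogen in place of propylcarbonyl on a nitrogen on an aromatic ring in a ring. Going by the values given here, no pair of measured compounds shows this exact change on its own, since compound 3, which also carries a hydrogen on that ring nitrogen, differs from compound 2 in the amide aryl group as well. The expected step of a 1.7-fold higher number from compound 2 to compound 4 (0.24 log units; within the scatter) is therefore a moderate rise in the number, near the edge of the scatter. Compound 4 is estimated at 25000 nM, with a range from 8000 nM to 80000 nM.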

Compound 4, concentration for 50% growth inhibition: 8760 nM
Beside the measured number, compound 4's estimate is 2.9-fold (0.46 log units) above it; the range from low to high includes it.
By their numbers in this assay, from the lowest: compounds 4 and 2 (each within the scatter of the next); then compounds 1 and 3 (each within the scatter of the next).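

In this assay, going by these compounds alone, replacing the propylcarbonyl on the ring nitrogen with hydrogen gives a 1.6-fold lower number from compound 2 to compound 4 (0.22 log units; within the scatter), the first reading of this change on its own, with the bis(trifluoromethyl)phenyl amide and the shared core left unchanged. In this pair, therefore, the propylcarbonyl is not needed for growth inhibition at this level, and the free ring nitrogen serves as well within the scatter of the assay. Nothing available here explains why the two compounds read alike.

The compounds shown do not tell whether a methyl or a benzoyl group on this nitrogen would move the number beyond the scatter. They also leave open whether the same change would read alike with a different aryl group on the amide, such as a pyridyl group.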